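Removing One Chloro Group from a Dichlorophenyl Amide

The source may report more compounds than this note shows. Statements on the series, on what has been measured and on what is new or still open speak of the compounds shown alone.

Compound 3 `O=C(CSc1nnc(-c2ccncc2)s1)Nc1ccc(Cl)cc1Cl` carries a dichlorophenyl amide on the shared core. In an ADME assay on BHK-21 cells (Mesocricetus auratus) for cytotoxicity, with a stated time of 3 days (a lower number here means that less compound is tolerated, a higher number that more compound is tolerated), compound 3 gives "not determined" (no result reported), so no single number stands for it. Its near relative compound 1 `CC(Sc1nnc(-c2ccncc2)s1)C(=O)Nc1ccc(Cl)cc1Cl` differs only by a methyl on the chain. Compound 1 reaches a limit of the assay in this assay, > 50000 nM, and this is a limit rather than a number. Compound 2 `O=C(CSc1nnc(-c2ccncc2)s1)NCc1ccccc1Cl`, the benzyl-type amide, likewise gives "not determined" (no result reported) in this assay. Among the measured compounds shown here, of the three entries, only one carries any reading at all, and that one is a limit (the limit of > 50000 nM in this assay, at which 1 of the 3 values shown sits).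

Compound 4 `O=C(CSc1nnc(-c2ccncc2)s1)Nc1ccc(Cl)cc1` has not yet been measured. It differs from compound 3 by hydrogen in place of chloro on an aromatic carbon. For the measured compounds named here, no pair of measured compounds is connected by a step, so the size of the step from compound 3 to compound 4 in this assay cannot be drawn from the data. Going by the values given here, the single reading available, the limit of compound 1, sits at the tolerant end, and with nothing to pull against it, no shift beyond the scatter is expected in either direction. Compound 4 is therefore expected to sit at about 50000 nM in this assay, within 20000 nM to 120000 nM, most likely again reported only as a limit.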

Compound 4, half-maximal cytotoxic concentration: > 50000 nM
Compound 4: a limit, no number; the forecaster's own chance of this, stated with the estimate: 70%; the middle value lies on the limit itself.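

In this assay compound 4 gives > 50000 nM, which is a limit and not a number. Among the compounds shown here, compound 3 has no single number either, so no step from compound 3 to compound 4 can be read. The compounds shown leave open whether going from 2,4-dichlorophenyl to 4-chlorophenyl changes the reading in this assay at all: the limit of > 50000 nM in this assay, at which 2 of the 4 values shown sit.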